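Thiophen-3-yl for thiophen-2-yl on the saturated ring carbon

The compounds below may be only part of what the source reports. "The series", "measured", "known", "first", "only" and "open" are said of these compounds alone.

Three compounds sharing one core were tested in an assay on membranes from HeLa cells for displacement of a labelled ligand from adenosine receptor A3 (Homo sapiens), read by scintillation counting, with a stated time of 180 min, tested at 1 uM; a lower number here means less inhibition, a higher number more inhibition at the concentration tested (going by the name of the read-out). Compound 1 `CC1=C(C(=O)OC(C)(C)C)C(c2ccsc2)NC(=O)N1` gives 1%. Compound 2 `CCSC(=O)C1=C(C)NC(=O)NC1c1ccsc1` gives 2%, and the step of a number 1 percentage points higher from compound 1 to compound 2 (within the scatter) concerns only the group on the carbonyl carbon. Compound 3 `CC1=C(C(=O)OC2CCCC2)C(c2cccs2)NC(=O)N1` gives 1%, level with compound 1 at the digits shown, the two together the lowest of the three numbers, and within the scatter of compound 2; all three numbers sit within the usual scatter of one another, so none of them can be called stronger or weaker than the rest.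

Compound 4 `CC1=C(C(=O)OC2CCCC2)C(c2ccsc2)NC(=O)N1` differs from compound 3 in one place: thiophen-3-yl in place of thiophen-2-yl on a saturated ring carbon. Going by the values given here, no measured step touches this position. Among the compounds with values here, the only measured step, from compound 1 to compound 2, changed the group on the carbonyl carbon and stayed within the scatter, so it does not speak to the thiophene. What can be said is that compound 1, which already carries thiophen-3-yl, and compound 3, which carries thiophen-2-yl, show the same value, although the two also differ at the ester. Compound 4 is therefore expected to show no step beyond the scatter, no change at the digits printed from compound 3 to compound 4 (within the scatter), in this assay. Compound 4 is estimated at 1%, between -6% and 9%.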

Compound 4, a percentage reported as inhibition, at one concentration (the size of the read-out at that concentration, not a potency): 5%
Beside the measured number, compound 4's estimate is 4 percentage points below it, within the range that was stated.
By their numbers in this assay, from the lowest: compounds 1, 3, 2 and 4 (each within the scatter of the next).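

In this assay, the change of thiophen-2-yl to thiophen-3-yl on the saturated ring carbon can now be read on its own, without a difference at the ester alongside it, and it gives a number 4 percentage points higher from compound 3 to compound 4 (within the scatter). With thiophen-3-yl held in place, compound 4 also adds two readings at the carbonyl side: cyclopentyloxy in place of ethylsulfanyl gives a number 3 percentage points higher from compound 2 to compound 4 (within the scatter), and cyclopentyl in place of tert-butyl on the oxygen gives a number 4 percentage points higher from compound 1 to compound 4 (within the scatter). Neither the position of the sulfur in the thiophene nor these groups on the carbonyl side has therefore moved the number beyond the scatter, and no separate measurement is at hand to account for these small readings.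

The compounds shown leave open whether a quite different group on the saturated ring carbon, such as a phenyl ring carrying an amine, would give a reading clear of the scatter in this assay. They also leave open whether a longer chain, such as n-hexyl, on the ester oxygen or a carboxylic acid in place of the ester would do so.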